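The compounds below may be only part of what the source reports. "The series", "measured", "known", "first", "only" and "open" are said of these compounds alone.

Working notes on the series. In a functional assay on HT-29 cells (Homo sapiens) for cytotoxicity, read by MTT assay, with a stated time of 72 h (a higher number here means that more compound is tolerated, a lower number that less compound is tolerated), compound 2 `C=CCOC(=O)Nc1ccc([Se]C#N)cc1` gives 72800 nM, nominally the largest of the three numbers, though its gaps to both other compounds are within the scatter: compound 3 `N#C[Se]c1ccc(NC(=O)Oc2ccccc2)cc1` gives 71700 nM, and compound 1 `Cc1ccc(OC(=O)Nc2ccc([Se][Se]c3ccc(NC(=O)Oc4ccc(C)cc4)cc3)cc2)cc1` gives 70900 nM. For the measured compounds named here, the one step measured on a single change, from compound 2 to compound 3, phenyl in place of allyl on an oxygen next to a carbonyl group, was a 1.0-fold lower number from compound 2 to compound 3 (0.01 log units; within the scatter). Compound 4 `N#C[Se]c1ccc(NC(=O)OCc2ccccc2)cc1` differs from compound 2 by phenyl in place of vinyl on a saturated chain carbon bound to an oxygen next to a carbonyl group. Going by the values given here, only the step of a 1.0-fold lower number from compound 2 to compound 3 (0.01 log units; within the scatter) bears on this change, and it showed nothing beyond the scatter, so no step beyond the scatter is expected in this assay, an expected 1.0-fold lower number from compound 2 to compound 4 (0.00 log units; within the scatter). Compound 4 is therefore estimated at 72000 nM, with a range of 40000 nM to 130000 nM.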

Compound 4, concentration lethal to 50% of the cells: 69100 nM
Estimate against measurement, compound 4: 1.0-fold (0.02 log units) above, within the range that was stated.
By their numbers in this assay, from the lowest: compounds 4, 1, 3 and 2 (each within the scatter of the next).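

In this assay, phenyl in place of vinyl on a saturated chain carbon bound to an oxygen next to a carbonyl group gives a 1.1-fold lower number from compound 2 to compound 4 (0.02 log units; within the scatter), and so a six-membered aromatic ring of carbon only enters at this place without a step beyond the scatter. The earlier single-change step concerned the group directly on that oxygen, whereas this one extends the same flat reading to the saturated chain carbon. No evidence bears on a cause for this result. As far as these compounds go, whether an amine, a carboxylic acid or a longer chain on this saturated chain carbon would give a step beyond the scatter remains open.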